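Methylating a Ring Amide Nitrogen in a Channel Blocker

The source may report more compounds than this note shows. Statements on the series, on what has been measured and on what is new or still open speak of the compounds shown alone.

Of the compounds shown here, two carry the same amide side chain and have been tested in a functional assay (Cavia porcellus) with sulfonylurea receptors; K-ATP channels (Homo sapiens) as the target; on this read-out lower numbers stand for stronger inhibition and higher numbers for weaker inhibition. Compound 1, `COc1cc(NC(=O)C(C)(O)C(F)(F)F)ccc1S(=O)(=O)c1ccccc1`, is an open-chain sulfone; in this assay compound 1 gives 5900 nM. Compound 2, `CC(O)(C(=O)Nc1ccc2c(c1)C(=O)NS2(=O)=O)C(F)(F)F`, closes the sulfonyl group into a five-membered ring bearing an amide-type nitrogen. In this assay compound 2 gives > 30000 nM, which is a limit of the assay rather than a measured number. Compound 2 therefore stands at the weak end of what is shown, sitting at the limit of > 30000 nM in this assay, at which 1 of the 2 values shown sits. For the measured compounds named here, no step between the two measured compounds has been worked out; they differ in more than one place, and what their two values show is simply that compound 1 lies inside the measurable range and compound 2 outside it.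

Compound 3, `CN1C(=O)c2cc(NC(=O)C(C)(O)C(F)(F)F)ccc2S1(=O)=O`, differs from compound 2 by methyl in place of hydrogen on an amide-type nitrogen in a ring. Going by the values given here, the measured pair offers no step of this kind to lean on, so the size and direction of the change from compound 2 to compound 3 in this assay are open. Compound 3 is expected to give about 20000 nM, between 5000 nM and 60000 nM. That estimate means an expected step of an at least 1.5-fold lower number from compound 2 to compound 3 (0.17 log units; that floor lies within the scatter) from a limit, and compound 3 may well again stay at the limit in this assay.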

Compound 3, half-maximal inhibitory concentration: 26000 nM
The estimate for compound 3 lay 1.3-fold (0.11 log units) below the measured number; measured number inside the range.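

With methyl in place of the hydrogen on this amide-type nitrogen, the closed-ring form now has a measured number in this assay: compound 3 gives 26000 nM, so this position accepts a methyl without the number moving out of the measurable range. Compound 2 stays the only compound shown whose value is a limit of the assay and not a number: the limit of > 30000 nM in this assay, at which 1 of the 3 values shown sits. All that can be read for this change is an at least 1.1-fold lower number from compound 2 to compound 3 (0.06 log units; that floor lies within the scatter), so the methyl may have made little real difference or a larger one, and the true size of the step stays hidden behind the limit.

The compounds shown leave open whether anything other than methyl on this nitrogen, such as an ethyl group, a longer chain or a chain ending in an amine or a carboxylic acid, would lower the number further. They also leave open whether the same change would act the same way with a different amide side chain, since every compound here carries the same one.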